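The source may hold more compounds than are shown below. What is called first, only, known or untested is meant among the compounds shown, and "the series" means these compounds.

Measured so far in a functional assay on U-937 cells (Homo sapiens) for cytotoxicity, read by MTT assay, with a stated time of 48 h; on this read-out higher numbers stand for weaker inhibition and lower numbers for stronger inhibition:
Compound 1 `Fc1cccc(-c2nc(Nc3ccccc3)c3ccccc3n2)c1`: > 50000 nM, a limit.
Compound 2 `COc1ccccc1Nc1nc(-c2cccc(F)c2)nc2ccc(F)cc12`: > 50000 nM, a limit.

Compound 2 gives no number, only the limit > 50000 nM. Going by the values given here, the series so far stands at the limit of > 50000 nM in this assay, at which 2 of the 2 values shown sit, so neither measured compound gives a true potency, and no step between measured compounds is available to size a change.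

Compound 3 `Fc1cccc(-c2nc(Nc3ccc(Cl)cc3)c3cc(F)ccc3n2)c1` is the next to be read. It carries 4-chlorophenyl in place of 2-methoxyphenyl on a nitrogen on an aromatic ring, and the rest of compound 2 is kept: 4-chlorophenyl in place of 2-methoxyphenyl on a nitrogen on an aromatic ring.

With nothing but limits to go on, the working assumption is that this exchange leaves the series weak. In this assay the estimated at least 1.2-fold lower number from compound 2 to compound 3 (0.09 log units; that floor lies within the scatter) is expected to stay within the scatter, and any real move could only be towards stronger inhibition. A further limit is quite possible for this compound. The expected value for compound 3 is 40000 nM, with an estimated range from 10000 nM to 100000 nM.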

Compound 3, half-maximal inhibitory concentration: 32700 nM
Compound 3: middle estimate off by 1.2-fold (0.09 log units), on the high side, within the range that was stated.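

In this assay, going by these compounds alone, 4-chlorophenyl in place of 2-methoxyphenyl on a nitrogen on an aromatic ring yields the first reading that is a true number and not a limit, so this position can now be followed on a measured value. Going by these compounds, the change gives an at least 1.5-fold lower number from compound 2 to compound 3 (0.18 log units; that floor lies within the scatter); the starting point of this step is a limit, so only a floor is known, the true size stays unknown, and a real gain in inhibition is not established. Even with this reading, inhibition in the series stays weak, and the limit still accounts for most of the data: the limit of > 50000 nM in this assay, at which 2 of the 3 values shown sit.

The compounds shown leave open whether the chlorine or the loss of the methoxy group carries any real move, as both differences sit in this one exchange and no compound separates them. On these data alone, how a carboxylic acid, or an amine on a longer chain, would read on this nitrogen also stays open, as does whether any group here can bring the series clearly away from the limit.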